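The source may report more compounds than this note shows. Statements on the series, on what has been measured and on what is new or still open speak of the compounds shown alone.

Compound 3 `Brc1ccc(OC[C@H]2CCN2)cn1` gives 0.17 nM in an assay on brain for binding affinity to Neuronal acetylcholine receptor; alpha4/beta2 (Rattus norvegicus), read by radioligand binding (on this read-out higher numbers stand for weaker inhibition and lower numbers for stronger inhibition), the highest of the three numbers recorded; compound 2 `Fc1ccc(OC[C@H]2CCN2)cn1` gives 0.066 nM and compound 1 `Cc1ccc(OC[C@@H]2CCN2)cn1`, which also carries a methyl, gives 0.057 nM. Compound 4 `Cc1ccc(OC[C@H]2CCN2)cn1` differs from compound 3 by methyl in place of bromo on an aromatic carbon. Within the data shown here, the only measured step at this position is a 2.6-fold higher number from compound 2 to compound 3 (0.41 log units; beyond the scatter), so exchanging the bromo for a smaller group moved the number down, and the methyl-bearing compound 1 sits among the lowest values. Compound 4 is therefore expected to shift a 2.4-fold lower number from compound 3 to compound 4 (0.39 log units; beyond the scatter) in this assay, a modest lowering. The estimate for compound 4 is 0.07 nM, with a plausible range from 0.03 nM to 0.17 nM.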

Compound 4, inhibition constant: 0.053 nM
For compound 4 the middle estimate is 1.3-fold (0.12 log units) above the measured one; the measured number falls inside the stated range.
By their numbers in this assay, from the lowest: compounds 4, 1 and 2 (each within the scatter of the next); then compound 3.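

Methyl in place of bromo gives a 3.2-fold lower number from compound 3 to compound 4 (0.51 log units; beyond the scatter) in this assay, a second step beyond the scatter that sets bromo apart at this position, while methyl in place of fluoro gives a 1.2-fold lower number from compound 2 to compound 4 (0.10 log units; within the scatter), so these two groups are not separated. The step of a 1.1-fold lower number from compound 1 to compound 4 (0.03 log units; within the scatter) shows that, with methyl, the drawn configuration at the saturated ring carbon has no effect beyond the scatter, a reading that rests on a single pair: the fact that compounds 1 and 4 differ only in the configuration as drawn

Going by these compounds, whether that also holds with bromo or fluoro stays open. So does how an amine, a carboxylic acid or a longer chain would read at this position.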